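Swapping Chlorine for Fluorine on a Shared Core

The source may hold more compounds than are shown below. What is called first, only, known or untested is meant among the compounds shown, and "the series" means these compounds.

Of the compounds shown here, two built on one shared core have been measured. Compound 1 `O=Cc1ccc(-c2cn3ccnc3c(-c3ccc4ncn(C5CCCCC5)c4c3)n2)cc1` carries a formyl group; in a functional assay on NCI-H226 cells (Homo sapiens) for inhibition, read by sulforhodamine B assay, with a stated time of 48 h, tested at 10 uM (on this read-out higher numbers stand for more inhibition at the one concentration tested (going by the name of the read-out) and lower numbers for less inhibition), compound 1 gives 0.53%. Going by the values given here, compound 2 `Clc1ccc(-c2cn3ccnc3c(-c3ccc4ncn(C5CCCCC5)c4c3)n2)cc1` gives 19.4% in this assay and stands highest of the two numbers, with compound 1 as its only neighbour. Among the compounds with values here, the single measured step connecting them is a number 18.9 percentage points higher from compound 1 to compound 2 (beyond the scatter).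

Compound 3 `Fc1ccccc1-c1cn2ccnc2c(-c2ccc3ncn(C4CCCCC4)c3c2)n1` is not yet measured. It differs from compound 2 by 2-fluorophenyl in place of 4-chlorophenyl on an aromatic carbon. Within the data shown here, no measured step makes this same exchange; the step from compound 1 to compound 2 shows only that replacing one group on an aromatic carbon can shift the read-out by a modest amount. Among the measured compounds shown here, because a number 18.9 percentage points higher from compound 1 to compound 2 (beyond the scatter) is the sole guide and does not cover this change, the expected step for compound 3 is a number 7.4 percentage points lower from compound 2 to compound 3 (within the scatter). The estimate for compound 3 is 12%, expected to fall between 0% and 35%.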

Compound 3, a percentage reported as inhibition, at one concentration (the size of the read-out at that concentration, not a potency): 28.7%
Compound 3: middle estimate off by 16.7 percentage points, on the low side; the measured number falls inside the stated range.
By their numbers in this assay, from the lowest: compound 1; then compounds 2 and 3 (each within the scatter of the next).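

In this assay, exchanging 4-chlorophenyl for 2-fluorophenyl on this aromatic carbon gives a number 9.3 percentage points higher from compound 2 to compound 3 (within the scatter), so these two halogen-bearing phenyl groups cannot be told apart on this read-out. Exchanging 4-formylphenyl for 2-fluorophenyl at the same carbon gives a number 28.2 percentage points higher from compound 1 to compound 3 (beyond the scatter), so among the three compounds, compound 1 is the one that stands apart, now against both halogen-bearing groups. Nothing shown here explains these numbers.

On these data alone, the exchange from compound 2 to compound 3 alters both the halogen and its place on the phenyl ring, so the contribution of each remains open, and a comparison with 2-chlorophenyl or 4-fluorophenyl would separate them. Also open, as far as these compounds go, is how this position responds to an unsubstituted phenyl group or to a phenyl ring bearing an amine or a carboxylic acid.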